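Benzyl ester to free acid: outlook for compound 4

The source may report more compounds than this note shows. Statements on the series, on what has been measured and on what is new or still open speak of the compounds shown alone.

Compound 3 `NCCCC[C@H](NC(=O)CN(c1nc(Cl)nc2[nH]cnc12)C1CC1)C(=O)OCc1ccccc1` gives 41.2% in a functional assay on the whole organism (Tail, strain ICR) with Mus musculus as the target, in the tail flick test, with a stated time of 60 min, at a dose of 25 umol/kg by the oral route (a lower number here means a weaker effect, a higher number a stronger effect of the compound at the dose given), the second highest of the three numbers recorded. Compound 1 `O=C(CN(c1nc(Cl)nc2[nH]cnc12)C1CC1)NCC(=O)OCc1ccccc1` gives 41.9% and compound 2 `O=C(CN(c1nc(Cl)nc2[nH]cnc12)C1CC1)N[C@@H](CO)C(=O)O` gives 39.8%; both lie within the scatter of compound 3, so no order among the three can be read. Going by the values given here, the one single-site step recorded, a number 0.7 percentage points lower from compound 1 to compound 3 (within the scatter), shows that putting 4-aminobutyl in place of hydrogen on a saturated chain carbon bound to an amide-type nitrogen and a carbonyl carbon leaves the read-out unchanged within the scatter.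

Compound 4 `NCCCC[C@H](NC(=O)CN(c1nc(Cl)nc2[nH]cnc12)C1CC1)C(=O)O` differs from compound 3 as follows: hydrogen in place of benzyl on an oxygen next to a carbonyl group. Among the compounds with values here, no recorded step isolates this change on its own. Compound 1 carries benzyloxycarbonyl and compound 2 carries carboxy, but the two also differ elsewhere, so only their values can be set side by side: compound 1 at 41.9% lies within the scatter of compound 2 at 39.8%. Nothing in the series therefore points to a shift beyond the scatter for this change.

On that basis the step of a number 1.2 percentage points lower from compound 3 to compound 4 (within the scatter) is expected to stay within the scatter. Compound 4 is accordingly estimated at 40%, with a range from 30% to 50%.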

Compound 4, a percentage reported as activity, at one dose (the size of the read-out at that dose, not a potency): 53.8%
Estimate against measurement, compound 4: 13.8 percentage points below; the measured number lies above the stated range.
By their numbers in this assay, from the lowest: compounds 2, 3 and 1 (each within the scatter of the next); then compound 4.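

In this assay, going by these compounds alone, the oxygen next to a carbonyl group is the first site where a single change separates two compounds: hydrogen in place of benzyl gives a number 12.6 percentage points higher from compound 3 to compound 4 (beyond the scatter) and lifts the read-out clear of the earlier compounds, which could not be told apart. Carboxy alone does not carry this level: compound 2 holds that group too, and with the carboxy kept, 3-aminopropyl in place of hydroxy on the saturated chain carbon gives a number 14 percentage points higher from compound 2 to compound 4 (beyond the scatter) as well, so the higher number is seen only where the free acid and the amine-bearing chain occur together. No measurement at hand bears on what lies behind these steps.

Open, as far as these compounds go, is whether a methyl ester or a primary amide in place of the benzyl ester would stay with compound 3 or move with compound 4, and whether the same change would give a comparable step on the unsubstituted chain of compound 1. Also open, from the compounds shown here alone, is how much of the level of compound 4 depends on the terminal amine, which a plain butyl chain or a 4-hydroxybutyl chain on the same carbon would test.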